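This account rests on a few compounds, and the source may have more. Where it says the series, first, only, none or still open, it means among the compounds named here.

Measured in a functional assay on EC9706 cells (Homo sapiens) for cytotoxicity, read by MTT assay, with a stated time of 72 h; on this read-out lower numbers stand for stronger inhibition and higher numbers for weaker inhibition:
- compound 1 `O=C(CSC(=S)N[C@H]1CCOC1=O)Nc1ccc(C(=O)/C=C/c2ccc(Cl)cc2)cc1`: 38900 nM
- compound 2 `O=C(CSC(=S)N[C@H]1CCOC1=O)Nc1ccc(C(=O)/C=C/c2ccc(Br)cc2)cc1`: 91200 nM
- compound 3 `O=C(CSC(=S)N[C@H]1CCOC1=O)Nc1ccc(C(=O)/C=C/c2ccc(F)cc2)cc1`: 46100 nM

Compound 3 stands within the scatter of both other compounds, as a 1.2-fold higher number from compound 1 to compound 3 (0.07 log units; within the scatter) and a 2.0-fold lower number from compound 2 to compound 3 (0.30 log units; within the scatter) show. Compound 4 `O=C(CSC(=S)N[C@H]1CCOC1=O)Nc1ccc(C(=O)/C=C/c2cccc(Cl)c2)cc1` differs from it as follows: 3-chlorophenyl in place of 4-fluorophenyl on a double-bonded chain carbon bound to a double-bonded chain carbon. The closest guidance comes from the halogen exchanges on an aromatic carbon. Besides those two steps, only a 2.3-fold higher number from compound 1 to compound 2 (0.37 log units; beyond the scatter) passes the scatter, and modestly. For the measured compounds named here, no measured step moves a halogen to another place, so that part of the change remains untested. A step no larger than the scatter is therefore expected in this assay. The estimated step is a 1.0-fold lower number from compound 3 to compound 4 (0.01 log units; within the scatter). For compound 4 the estimated value is 45000 nM, with an expected range of 20000 nM to 100000 nM.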

Compound 4, half-maximal inhibitory concentration: 32500 nM
For compound 4 the middle estimate is 1.4-fold (0.14 log units) above the measured one; low and high end bracket the measured number.
By their numbers in this assay, from the lowest: compounds 4, 1, 3 and 2 (each within the scatter of the next, the first and the last beyond it).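

In this assay, for the compounds shown here, 3-chlorophenyl in place of 4-chlorophenyl gives a 1.2-fold lower number from compound 1 to compound 4 (0.08 log units; within the scatter), the first measured step that moves a halogen to another place, and that move stays within the scatter. Against 4-fluorophenyl, the change gives a 1.4-fold lower number from compound 3 to compound 4 (0.15 log units; within the scatter), also within the scatter, whereas against 4-bromophenyl it gives a 2.8-fold lower number from compound 2 to compound 4 (0.45 log units; beyond the scatter), so compound 2 now lies beyond the scatter of both chloro compounds, though not of compound 3. No measurement shown here accounts for these steps.

Going by these compounds, whether a methoxy group, an amine or a carboxylic acid in place of the halogen would stay within this narrow range remains open. So does whether fluoro or bromo, moved in the same way, would behave as chloro does.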